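A few compounds are considered here, and "the series" means these few. Any claim that something is new, unique, unknown or untested is made for them only; others in the source may bear on it.

Compound 1 `CCCCCCCC#Cc1ccc(CCC(=O)O)cc1` gives 84% in a functional assay on 1321-N1 cells for agonist activity at Free fatty acid receptor 1 (Homo sapiens), read by calcium flux, with a stated time of 0.4 s; on this read-out higher numbers stand for larger maximal responses and lower numbers for smaller maximal responses.
Compound 2 `C/C=C\C#Cc1ccc(CCC(=O)O)c(F)c1` gives 91% in this assay.
Compound 3 `O=C(O)CCc1ccc(C#CC2CCCCC2)cc1` gives 98% in this assay.

All three measured compounds share a core carrying a propanoic acid side chain and an alkyne-linked group; they differ in what sits on the alkyne and in the presence of a fluorine. Compound 2 stands second highest of the three numbers, but its gap to compound 1 on one side and to compound 3 on the other both lie within the usual scatter of repeated measurements, so the three compounds cannot be told apart on these data.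

Compound 4 `C/C=C/C#Cc1ccc(CCC(=O)O)c(F)c1` is the next compound of interest. the two compounds have the same atoms and bonds and differ only in configuration as drawn: 1 of 1 stereo elements differ; a double bond is drawn Z in compound 2 and E in compound 4

For the measured compounds named here, no step between two measured compounds is available to guide the expectation, and no measured pair differs in the geometry of this double bond. With the same atoms and bonds present in both compounds, the expected step in this assay is none beyond the scatter, in either direction. Compound 4 is therefore expected to give about 90%, with a likely range from 78% to 100%. The expected change a number 1 percentage points lower from compound 2 to compound 4 (within the scatter) is estimated to stay within the scatter.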

Compound 4, largest response reached (reported as efficacy), in percent of the reference or control that the assay uses: 97%
Beside the measured number, compound 4's estimate is 7 percentage points below it; the range from low to high includes it.
By their numbers in this assay, from the lowest: compounds 1, 2, 4 and 3 (each within the scatter of the next, the first and the last beyond it).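

This pair gives the first direct reading of double-bond geometry among these compounds: in this assay the step is a number 6 percentage points higher from compound 2 to compound 4 (within the scatter). On this read-out, then, the Z and E forms cannot be told apart, and the geometry of this double bond shows no clear bearing on the maximal response. The comparison is a clean one, because only one feature separates the pair: the fact that compounds 2 and 4 differ only in the configuration as drawn

No pair shown differs in the fluorine alone, so its contribution cannot be read from these compounds. Going by these compounds, it also remains open how the maximal response would look with a hydroxyl group or an amine at the end of the group on the alkyne, or with a saturated chain in place of the double bond.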